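This account rests on a few compounds, and the source may have more. Where it says the series, first, only, none or still open, it means among the compounds named here.

In an ADME assay on CCRF-HSB-2 cells (Homo sapiens) for cytotoxicity, with a stated time of 7 days (a higher number here means that more compound is tolerated, a lower number that less compound is tolerated), compound 1 `CCCSc1nc(N)nc2c1ncn2/C=C1/CC1(CO)CO` gives 98000 nM. Compound 2 `CCCNc1nc(N)nc2c1ncn2/C=C1/CC1(CO)CO` stands only at a limit, > 20000 nM. Compound 3 `CCCCCOc1nc(N)nc2c1ncn2/C=C1/CC1(CO)CO` differs from it by pentyloxy in place of propylamino on an aromatic carbon, with pentyloxy in place of propylamino on an aromatic carbon. Among the measured compounds shown here, the one measured step, a step that the limit leaves unreadable from compound 1 to compound 2, has no readable size, and the limit of > 20000 nM in this assay, at which 1 of the 2 values shown sits, is the only evidence on it. For the measured compounds named here, the sole exact reading is compound 1 at 98000 nM, so a high value is expected, with no firm direction and no change beyond the scatter in this assay. The estimated step is a step that the limit leaves unreadable from compound 2 to compound 3. For compound 3 the expected value is 40000 nM, with an estimated range of 12000 nM to 100000 nM.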

Compound 3, half-maximal cytotoxic concentration: > 20000 nM
Compound 3: a limit, no number; the forecaster's own chance of this, stated with the estimate: 45%; the middle value is on the limit's open side.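

Among the compounds shown here, compound 3, like compound 2, stands only at a limit in this assay, and no step among compound 1, compound 2 and compound 3 can be read. From the compounds shown here alone, how propylsulfanyl, propylamino and pentyloxy compare on the shared core stays open.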